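The compounds below may be only part of what the source reports. "The series", "measured", "known", "first", "only" and "open" are said of these compounds alone.

Of the compounds shown here, two of a shared core have been measured in an assay on membranes from HEK293 cells for displacement of a labelled ligand from adenosine receptor A2b (Homo sapiens), read by scintillation counting, with a stated time of 30 min, tested at 1 uM; on this read-out higher numbers stand for more inhibition at the one concentration tested (going by the name of the read-out) and lower numbers for less inhibition. Compound 1 `CCCC(=O)C1=C(C)NC(=O)NC1c1ccsc1` gives 9%. Compound 2 `CCN(CC)C(=O)C1=C(C)NC(=O)NC1c1cccs1` gives 22%, the higher of the two numbers, and the gap between compound 2 and compound 1 lies beyond the usual scatter of this assay. Within the data shown here, the two differ in more than one place, so their values show only that compound 2 stands higher, not which change carries the difference.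

Compound 3 `CCN(CC)C(=O)C1=C(C)NC(=O)NC1c1ccsc1` is the compound not yet measured. It differs from compound 2 in a single place: thiophen-3-yl in place of thiophen-2-yl on a saturated ring carbon. Among the measured compounds shown here, no pair of measured compounds shows this change on its own, so its effect in this assay is not known from the data. Compound 1 carries the thiophen-3-yl group and sits low, yet it also carries a different group of seven heavy atoms, so it cannot settle the question.

The author expects compound 3 to give 15%, within a range from 3% to 30%. This estimate means a step of a number 7 percentage points lower from compound 2 to compound 3 (within the scatter), expected to be small and downward, and possibly not beyond the scatter.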

Compound 3, a percentage reported as inhibition, at one concentration (the size of the read-out at that concentration, not a potency): 11%
Beside the measured number, compound 3's estimate is 4 percentage points above it, within the range that was stated.
By their numbers in this assay, from the lowest: compounds 1 and 3 (each within the scatter of the next); then compound 2.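

In this assay, among these compounds, moving the point of attachment of the thiophene alone gives a number 11 percentage points lower from compound 2 to compound 3 (beyond the scatter), so with the diethylamino amide held fixed, the thiophen-2-yl group on the saturated ring carbon stands higher than the thiophen-3-yl group, which no earlier pair could show. Among the compounds shown here, with thiophen-3-yl held fixed, diethylamino in place of propyl on the carbonyl carbon gives a number 2 percentage points higher from compound 1 to compound 3 (within the scatter), so of these two single changes only the one in the thiophene's attachment has a step beyond the scatter. The data shown offer no measured evidence that accounts for this step.

On these data alone, it remains open whether thiophen-2-yl would also stand higher than thiophen-3-yl with propyl on the carbonyl carbon, and how a phenyl or furan-2-yl group on the saturated ring carbon, or a longer chain on the carbonyl carbon, would read in this assay. As far as these compounds go, compound 2 gives 22% at a single concentration, so its potency and that of the other compounds also remain open, as does any effect of these changes on other adenosine receptors.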